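One Methoxy Less on a Silyl-Protected Compound

The source may report more compounds than this note shows. Statements on the series, on what has been measured and on what is new or still open speak of the compounds shown alone.

Compound 1, `COc1ccc(C2=C(c3cc(OC)c(OC)c(OC)c3)C(=O)CC2O[SiH2]C(C)(C)C)cc1OC`, was tested in an ADME assay on PA-1 cells (Homo sapiens) for cytotoxicity, read by MTT assay, with a stated time of 72 h; a higher number here means a weaker inhibitor, a lower number a stronger inhibitor. In this assay compound 1 gives > 100 ug/mL, which is a limit of the assay and not a number, as stated by the limit of > 100 ug/mL in this assay, at which 2 of the 3 values shown sit. Two companions frame the picture. Compound 2, `COc1ccc(C2=C(c3cc(OC)c(OC)c(OC)c3)C(=O)C(OC(C)=O)C2)cc1OC(C)C`, carries an acetate and an isopropoxy instead of the silyl group and one methoxy; in this assay compound 2 gives > 100 ug/mL, again a limit rather than a number. Compound 3, `COc1ccc(C2=C(c3cc(OC)c(OC)c(OC)c3)C(=O)C(O)C2)cc1`, bears a free hydroxy and only one methoxy on its pendant ring; in this assay compound 3 gives < 1 ug/mL, a limit at the strong end, as stated by the limit of < 1 ug/mL in this assay, at which 1 of the 3 values shown sits. Compound 1 therefore stands with compound 2 at the weak limit, while compound 3 alone reaches the strong one.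

Compound 4, `COc1ccc(C2=C(c3cc(OC)c(OC)c(OC)c3)C(=O)CC2O[SiH2]C(C)(C)C)cc1`, differs from compound 1 in a single place: hydrogen in place of methoxy on an aromatic carbon. Within the data shown here, compound 1 shows only a limit, and no measured step starts from it. The size of the change in this assay cannot be read from the data. Compound 3 shares the 4-methoxyphenyl but differs elsewhere as well, so it does not settle the matter. In this assay compound 4 is expected to give 60 ug/mL, between 5 ug/mL and 200 ug/mL. The expected step of an at least 1.6-fold lower number from compound 1 to compound 4 (0.22 log units; that floor lies within the scatter) is small, most likely leaving the value near the weak limit.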

Compound 4, half-maximal inhibitory concentration: > 100 ug/mL
Compound 4: a limit, no number; the forecaster's own chance of this, stated with the estimate: 55%; middle value at least 1.6-fold (0.22 log units) away from the limit.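

In this assay compound 4 gives > 100 ug/mL, a limit and not a number. Compound 1 stands at a limit of the same kind, so the step between compound 1 and compound 4 cannot be read. As far as these compounds go, whether hydrogen in place of methoxy changes the value at all, and by how much, stays open.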